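The source may report more compounds than this note shows. Statements on the series, on what has been measured and on what is new or still open speak of the compounds shown alone.

Measured compounds in this set:

- compound 1 `COC[C@H]1CN(c2ccc(OCC(C)O)cc2)C(=O)O1`: 1.17
- compound 2 `COC[C@H]1CN(c2ccc(CCCO)cc2)C(=O)O1`: 1.27
- compound 3 `COC[C@H]1CN(c2ccc(OCCO)cc2)C(=O)O1`: 0.77

In a physicochemical assay for lipophilicity (on this read-out lower numbers stand for lower lipophilicity and higher numbers for higher lipophilicity), compound 3 gives 0.77, the lowest of the three numbers. The step of a number 0.40 log units lower from compound 1 to compound 3 (beyond the scatter) and the step of a number 0.50 log units lower from compound 2 to compound 3 (beyond the scatter) both set it apart from the other two beyond the scatter, while the step of a number 0.10 log units higher from compound 1 to compound 2 (within the scatter) leaves compound 1 and compound 2 undistinguished.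

Compound 4 `COC[C@H]1CN(c2ccc(CCO)cc2)C(=O)O1` has not yet been measured. It differs from compound 3 in one place: 2-hydroxyethyl in place of 2-hydroxyethoxy on an aromatic carbon.

The step that bears on this most directly is a number 0.50 log units lower from compound 2 to compound 3 (beyond the scatter), which runs in the opposite sense and concerns a closely related pair of groups on the same aromatic carbon; read in reverse it points to an increase when the ether oxygen is absent. Compound 4 carries one chain carbon fewer than compound 2, so the full size of that reversed step is not expected to be reached. The step of a number 0.10 log units higher from compound 1 to compound 2 (within the scatter) adds little, since it lies within the scatter. A modest rise in this assay is therefore expected for compound 4, about a number 0.23 log units higher from compound 3 to compound 4 (within the scatter).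

For compound 4 the estimate in this assay is 1, with a range from 0.7 to 1.3.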

Compound 4, partition coefficient: 1.13
Compound 4: middle estimate off by 0.13 log units, on the low side; measured number inside the range.
By their numbers in this assay, from the lowest: compound 3; then compounds 4, 1 and 2 (each within the scatter of the next).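

In this assay, 2-hydroxyethyl in place of 2-hydroxyethoxy on the aromatic carbon, para to a group of 9 heavy atoms, gives a number 0.36 log units higher from compound 3 to compound 4 (beyond the scatter), a step beyond the scatter. Unlike the earlier step between the 3-hydroxypropyl and 2-hydroxyethoxy groups, this one keeps the two carbons of the chain and exchanges only the oxygen attached to the aromatic carbon, so a difference at this position appears without a change in chain carbon count. The other two new steps, a number 0.14 log units lower from compound 2 to compound 4 (within the scatter) and a number 0.04 log units lower from compound 1 to compound 4 (within the scatter), stay within the scatter, leaving compound 3 as the only one of the four set apart, and no supporting data on the origin of these differences are available.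

The compounds shown carry only a terminal hydroxy group on short chains, so it remains open whether the step between 2-hydroxyethyl and 2-hydroxyethoxy keeps its size when that hydroxy group is replaced by an amine or a carboxylic acid. The same question stands for a longer chain, such as 4-hydroxybutyl against 3-hydroxypropoxy, at this position.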